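The source may hold more compounds than are shown below. What is called first, only, known or untested is meant among the compounds shown, and "the series" means these compounds.

Working notes on the series, read in a functional assay on OVCAR-8 cells (Homo sapiens) for antiproliferative activity; on this read-out lower numbers stand for stronger inhibition and higher numbers for weaker inhibition. Compound 1 (`CNC(=O)C[C@@H]1C[C@@H](c2ccc(Cl)c(Cl)c2)[C@H](NC(=O)c2cc(-c3c(Cl)cnn3C)c(Cl)o2)CN1`) gives 1130 nM, compound 2 (`Cn1ncc(Cl)c1-c1cc(C(=O)N[C@@H]2CN[C@H](CCN3CCCCC3)C[C@H]2c2ccc(Cl)c(Cl)c2)oc1Cl`) gives 1660 nM and compound 3 (`Cn1ncc(Cl)c1-c1cc(C(=O)N[C@@H]2CN[C@H](CCO)C[C@H]2c2ccc(Cl)c(Cl)c2)oc1Cl`) gives 610 nM. Compound 3 is separated by more than the scatter from only one of the other two compounds. The two steps that place it are a 1.9-fold lower number from compound 1 to compound 3 (0.27 log units; within the scatter), and a 2.7-fold lower number from compound 2 to compound 3 (0.43 log units; beyond the scatter).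

Compound 4 (`Cn1ncc(Cl)c1-c1cc(C(=O)N[C@@H]2CN[C@H](CCN3CCCC3)C[C@H]2c2ccc(Cl)c(Cl)c2)oc1Cl`) differs from compound 3 as follows: pyrrolidin-1-yl in place of hydroxy on a saturated chain carbon, two bonds along the chain from a saturated ring carbon. In words, pyrrolidin-1-yl stands in place of hydroxy on a saturated chain carbon, two bonds along the chain from a saturated ring carbon.

Going by the values given here, the step that bears most directly is the modest one between piperidin-1-yl and hydroxy at this same place, read here in reverse, since compound 2 is the only measured compound with a non-aromatic ring at the end of this chain. The step of a 1.5-fold higher number from compound 1 to compound 2 (0.17 log units; within the scatter) adds little, as it stays within the scatter. Among the compounds with values here, no compound with pyrrolidin-1-yl has been measured, so the transfer from piperidin-1-yl is an assumption. Within the data shown here, a modest step towards a higher number in this assay is therefore expected, of similar size to the one seen with compound 2. The expected step is a 2.1-fold higher number from compound 3 to compound 4 (0.33 log units; beyond the scatter). Compound 4 is expected at 1300 nM, with an estimated range of 600 nM to 2800 nM.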

Compound 4, half-maximal inhibitory concentration: 1840 nM
Compound 4: the middle estimate sits 1.4-fold (0.15 log units) below what was measured; low and high end bracket the measured number.
By their numbers in this assay, from the lowest: compounds 3, 1, 2 and 4 (each within the scatter of the next, the first and the last beyond it).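

In this assay, pyrrolidin-1-yl on the saturated chain carbon gives a 3.0-fold higher number from compound 3 to compound 4 (0.48 log units; beyond the scatter), and this second ring at the end of the chain, alongside a 2.7-fold lower number from compound 2 to compound 3 (0.43 log units; beyond the scatter), shows that the separation from hydroxy at this place does not rest on compound 2 alone. Exchanging one ring for the other gives a 1.1-fold higher number from compound 2 to compound 4 (0.04 log units; within the scatter), and a 1.6-fold higher number from compound 1 to compound 4 (0.21 log units; within the scatter) also stays within the scatter, so at this resolution neither piperidin-1-yl and pyrrolidin-1-yl nor methylcarbamoyl and the (pyrrolidin-1-yl)methyl form of the chain can be told apart. No supporting measurement bears on why hydroxy and the rings differ here.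

The compounds shown leave open whether the separation belongs to the ring itself or to the loss of hydroxy, and a dimethylamino group, a morpholin-4-yl ring or a methoxy group at the end of the same chain would help to separate these readings. They also leave open how far the result depends on chain length, which a longer chain ending in hydroxy or pyrrolidin-1-yl would address.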